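Swapping the amide substituent on the weakest of three analogues

A few compounds are considered here, and "the series" means these few. Any claim that something is new, unique, unknown or untested is made for them only; others in the source may bear on it.

Of the compounds shown here, three sharing one core have been measured in a functional assay on A549 cells (Homo sapiens) for antiproliferative activity, read by CCK-8 assay, with a stated time of 48 h; a lower number here means a stronger inhibitor, a higher number a weaker inhibitor. Compound 1 `O=C(Nc1ccc(Cl)cc1)c1cc(Oc2ccc(/C=C/c3ccccn3)cc2)ccn1` gives 16200 nM, compound 2 `CNC(=O)c1cc(Oc2ccc(/C=C/c3ccncc3)cc2)ccn1` gives 13200 nM, and compound 3 `O=C(Nc1ccc(Cl)cc1)c1cc(Oc2ccc(/C=C/c3ccncc3)cc2)ccn1` gives 62100 nM. On these numbers compound 3 stands highest, with a 3.8-fold higher number from compound 1 to compound 3 (0.58 log units; beyond the scatter) and a 4.7-fold higher number from compound 2 to compound 3 (0.67 log units; beyond the scatter), both beyond the scatter, so compound 3 is the weakest inhibitor of the set.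

Compound 4 `O=C(NCc1ccc(F)cc1)c1cc(Oc2ccc(/C=C/c3ccncc3)cc2)ccn1` differs from compound 3 in a single place: 4-fluorobenzyl in place of 4-chlorophenyl on an amide-type nitrogen. Among the compounds with values here, the one measured step that bears on this change is the one on the amide-type nitrogen, a 4.7-fold higher number from compound 2 to compound 3 (0.67 log units; beyond the scatter), where exchanging methyl for 4-chlorophenyl made the number modestly worse. Since 4-fluorobenzyl is neither the methyl of compound 2 nor the 4-chlorophenyl of compound 3, compound 4 is expected to land between those two values, which means a modestly lower number than compound 3 in this assay, with the step expected to be a 2.1-fold lower number from compound 3 to compound 4 (0.32 log units; beyond the scatter). The estimate for compound 4 in this assay is therefore 30000 nM, expected to fall between 10000 nM and 90000 nM.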

Compound 4, half-maximal inhibitory concentration: 18200 nM
Estimate against measurement, compound 4: 1.6-fold (0.22 log units) above; measured number inside the range.
By their numbers in this assay, from the lowest: compounds 2, 1 and 4 (each within the scatter of the next); then compound 3.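

On the amide-type nitrogen in this assay, the high number of compound 3 proves specific to the 4-chlorophenyl group rather than common to every aromatic ring carried there, with a 3.4-fold lower number from compound 3 to compound 4 (0.53 log units; beyond the scatter) on going to 4-fluorobenzyl. That single step combines two differences, a saturated chain carbon joining the ring to the nitrogen and fluorine in place of chlorine, and the data cannot separate them. The methyl and 4-fluorobenzyl groups on this nitrogen cannot be told apart in this assay, with a 1.4-fold higher number from compound 2 to compound 4 (0.14 log units; within the scatter), and no supporting measurement is available to explain any of these numbers.

Going by these compounds, what remains open is which of the two differences carries the step: 4-fluorophenyl and 4-chlorobenzyl on the same nitrogen would each change only one of them, while an unsubstituted benzyl would show whether the halogen matters at all. Also open, on these data alone, is how a longer chain such as 2-phenylethyl, or a chain ending in an amine, would behave at this position, and whether 4-fluorobenzyl would give a similar number alongside the pyridin-2-yl group of compound 1.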